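From 4-Iodophenyl to 3-Aminophenyl at a Cytotoxicity Limit

This account rests on a few compounds, and the source may have more. Where it says the series, first, only, none or still open, it means among the compounds named here.

In an ADME assay on L929 cells (Mus musculus) for cytotoxicity, read by resazurin assay, with a stated time of 72 h (a lower number here means a stronger inhibitor, a higher number a weaker inhibitor), compound 3 (`O=C(/C=C/c1ccc2c(c1)B(O)OC2)c1ccc(I)cc1`) gives > 10 ug/mL as a limit and not a number. Compound 1 (`O=C(/C=C/c1ccc2c(c1)B(O)OC2)c1ccco1`) gives > 10 ug/mL as a limit too. Compound 2 (`O=C(/C=C/c1ccc2c(c1)B(O)OC2)c1ccc(Br)cc1`) likewise gives > 10 ug/mL as a limit. The evidence so far comes down to the limit of > 10 ug/mL in this assay, at which 3 of the 3 values shown sit, and offers no measured number. Compound 4 (`Nc1cccc(C(=O)/C=C/c2ccc3c(c2)B(O)OC3)c1`) carries 3-aminophenyl in place of 4-iodophenyl on a carbonyl carbon. Within the data shown here, three measured steps bear on this change. Replacing furan-2-yl on a carbonyl carbon gave a step that the two limits leave unreadable from compound 1 to compound 2 and a step that the two limits leave unreadable from compound 1 to compound 3 in turn, and iodo in place of bromo gave a step that the two limits leave unreadable from compound 2 to compound 3 as well. Among the measured compounds shown here, none of these has a readable size, so none can be carried over, and in this assay no step of known size or direction is expected. The expected change is a step that the limit leaves unreadable from compound 3 to compound 4 on this estimate. Compound 4 is expected at 15 ug/mL (estimated range 5 ug/mL to 50 ug/mL).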

Compound 4, half-maximal inhibitory concentration: 10 ug/mL
For compound 4 the middle estimate is 1.5-fold (0.18 log units) above the measured one; measured number inside the range.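

In this assay, among these compounds, compound 4 gives 10 ug/mL, the first value in this set that is a number and not a limit. Among the compounds shown here, replacing 4-iodophenyl with 3-aminophenyl on the carbonyl carbon is therefore the first change here to show a direction, a number no higher from compound 3 to compound 4 (the limit leaves the size open), and the same holds for a number no higher from compound 2 to compound 4 (the limit leaves the size open) and for a number no higher from compound 1 to compound 4 (the limit leaves the size open). The size of all three steps remains unreadable, and the series still rests largely on one limit: the limit of > 10 ug/mL in this assay, at which 3 of the 4 values shown sit.

Compound 4 differs from compound 3 both in the group on the phenyl ring and in where that group stands, and these two changes cannot be told apart here. A 4-aminophenyl or a 3-iodophenyl group on the same carbonyl carbon would separate them.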